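Swapping a Tert-Butyl for a Pentyl Chain

The source may report more compounds than this note shows. Statements on the series, on what has been measured and on what is new or still open speak of the compounds shown alone.

Two measured compounds share one core and differ only in the group on an oxygen next to a carbonyl group. Compound 1 `CCOC(=O)N1CCN(C(=O)c2nc(Nc3cc(C4CC4)[nH]n3)c3cc(Cl)ccc3n2)C[C@H]1C` carries an ethyl there, and in an assay for inhibition of serine/threonine-protein kinase PAK 4 (Homo sapiens), read by FRET and Z'-LYTE, with a stated time of 60 min, tested at 0.5 uM, in the presence of a further agent that is not named here (a higher number here means a stronger effect of the compound at the concentration tested, a lower number a weaker effect), compound 1 gives 42.4%. Compound 2 `C[C@@H]1CN(C(=O)c2nc(Nc3cc(C4CC4)[nH]n3)c3cc(Cl)ccc3n2)CCN1C(=O)OC(C)(C)C` carries a tert-butyl instead, and in this assay compound 2 gives 0.1%, the lowest of the two numbers. Among the compounds with values here, the single known step, a number 42.3 percentage points lower from compound 1 to compound 2 (beyond the scatter), is the only one that bears on the next move. Compound 3 `CCCCCOC(=O)N1CCN(C(=O)c2nc(Nc3cc(C4CC4)[nH]n3)c3cc(Cl)ccc3n2)C[C@H]1C` is not yet measured; its change from compound 2 is pentyl in place of tert-butyl on an oxygen next to a carbonyl group. Since the ethyl of compound 1 gave 42.4% while the tert-butyl of compound 2 gave 0.1%, a pentyl is expected to recover part of that loss, with an expected step of a number 19.9 percentage points higher from compound 2 to compound 3 (beyond the scatter). For compound 3 the estimate in this assay is 20%, with a range from 0% to 50%.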

Compound 3, a percentage reported as inhibition, at one concentration (the size of the read-out at that concentration, not a potency): -3.8%
Compound 3: middle estimate off by 23.8 percentage points, on the high side, and the stated range ends above it.
By their numbers in this assay, from the lowest: compounds 3 and 2 (each within the scatter of the next); then compound 1.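

In this assay, the change of tert-butyl to pentyl reads as a number 3.9 percentage points lower from compound 2 to compound 3 (within the scatter), so these two groups cannot be told apart at this position. Going from ethyl to the unbranched pentyl chain gives a number 46.2 percentage points lower from compound 1 to compound 3 (beyond the scatter), a loss as clear as the one seen with tert-butyl, so branching is not needed for the read-out to fall away among these compounds. Nothing measured here explains why the ethyl compound alone keeps a clear effect.

The compounds shown leave open where between ethyl and pentyl the effect disappears, which a propyl or butyl chain on the same oxygen would help to locate. They also leave open whether a methyl there would hold, raise or lower the effect seen with ethyl.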